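Saturating the Allyl Chain of Compound 1

The source may hold more compounds than are shown below. What is called first, only, known or untested is meant among the compounds shown, and "the series" means these compounds.

Compound 1 `C=CCNc1nc(NCc2ccc(C(=O)Nc3ccc(F)cc3)cc2)c2ccccc2n1` bears an allylamino group. Among the measured compounds shown here, in a functional assay on HCT-116 cells (Homo sapiens) for inhibition, read by luminescence and resazurin assay, with a stated time of 3 days (on this read-out higher numbers stand for weaker inhibition and lower numbers for stronger inhibition), compound 1 gives 14000 nM, the highest of the two numbers measured so far. Compound 2 `CN1CCN(c2nc(NCc3ccc(NC(=O)c4ccc(F)cc4)cc3)c3ccccc3n2)CC1` differs from compound 1 in several places. In this assay, for the measured compounds named here, compound 2 gives 1800 nM, a lower number by a margin beyond the usual scatter; no single-change step links these two compounds, so the values alone are what they show. Compound 3 `CCCNc1nc(NCc2ccc(C(=O)Nc3ccc(F)cc3)cc2)c2ccccc2n1` is the closer neighbour of compound 1: ethyl in place of vinyl on a saturated chain carbon bound to a nitrogen on an aromatic ring. The two measured compounds give no hint of how a change of this small size should move the read-out, so the expected step is no change at the digits printed from compound 1 to compound 3 (within the scatter), within the scatter and in no particular direction. The estimated value for compound 3 in this assay is 14000 nM, with a range from 5000 nM to 40000 nM.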

Compound 3, half-maximal inhibitory concentration: 1500 nM
Compound 3: the middle estimate sits 9.3-fold (0.97 log units) above what was measured, and the stated range ends above it.
By their numbers in this assay, from the lowest: compounds 3 and 2 (each within the scatter of the next); then compound 1.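

Replacing vinyl with ethyl, on a saturated chain carbon bound to a nitrogen on an aromatic ring, gives in this assay a 9.3-fold lower number from compound 1 to compound 3 (0.97 log units; beyond the scatter), so the read-out responds to a change at this position. Two heavy atoms leave and two enter, and the hydrogen-bond donor and acceptor counts of the two groups are equal; the counted difference is the double bond outside aromatic rings, present in allyl and absent from propyl. This is the first single-change step among these compounds, so a difference can now be tied to one place rather than spread over several.

Nothing available explains why the propylamino compound gives the lower number. Going by these compounds, whether a longer chain such as butyl, or a hydroxyl at the end of the propyl chain, would lower or raise the number remains open.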